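The source may report more compounds than this note shows. Statements on the series, on what has been measured and on what is new or still open speak of the compounds shown alone.

Measured compounds:
Compound 1 `Cc1ccc(NC(=O)COc2ccc3cc(/C=C4/SC(=O)NC4=O)ccc3c2)cc1` with 1700 nM
Compound 2 `O=C(COc1ccc2cc(/C=C3/SC(=O)NC3=O)ccc2c1)Nc1ccc(F)cc1F` with 3900 nM

In an assay on isolated protein for inhibition of histone deacetylase 4 (Homo sapiens), with a stated time of 1 h (a lower number here means a stronger inhibitor, a higher number a weaker inhibitor), compound 2 stands at the higher of the two numbers, its nearest neighbour being compound 1, which gives 1700 nM. Among the compounds with values here, the one measured step, a 2.3-fold higher number from compound 1 to compound 2 (0.36 log units; beyond the scatter), is modest but beyond the scatter.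

Compound 3 `Cc1ccc(NC(=O)COc2ccc3cc(/C=C4/SC(=O)NC4=O)ccc3c2)cc1Cl` has not yet been measured. It differs from compound 2 in one place: 3-chloro-4-methylphenyl in place of 2,4-difluorophenyl on an amide-type nitrogen. Compound 3 thus carries the 4-methylphenyl pattern of compound 1 with an added chlorine, so the step of a 2.3-fold higher number from compound 1 to compound 2 (0.36 log units; beyond the scatter) bears on it in reverse. Within the data shown here, a return toward the number of compound 1 is therefore expected, giving a modest fall, a 2.6-fold lower number from compound 2 to compound 3 (0.41 log units; beyond the scatter); the chlorine has no precedent here, so the range stays wide. Compound 3 is expected to give 1500 nM, between 600 nM and 4000 nM.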

Compound 3, half-maximal inhibitory concentration: 1100 nM
Compound 3: the middle estimate sits 1.4-fold (0.13 log units) above what was measured; low and high end bracket the measured number.
By their numbers in this assay, from the lowest: compounds 3 and 1 (each within the scatter of the next); then compound 2.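

In this assay, 3-chloro-4-methylphenyl in place of 2,4-difluorophenyl on the amide-type nitrogen gives a 3.5-fold lower number from compound 2 to compound 3 (0.55 log units; beyond the scatter), so replacing the whole substituted phenyl group at this position moves the number by more than the scatter. Chloro in place of hydrogen on an aromatic carbon gives a 1.5-fold lower number from compound 1 to compound 3 (0.19 log units; within the scatter), so adding the chlorine to the 4-methylphenyl group produces no change that can be told from the scatter. Nothing given here explains the size of either step.

The compounds shown leave open whether one fluorine or both set the higher number of compound 2; its step to compound 3 exchanges all the ring substituents at once. They also leave open how this position would respond to a methoxy group, an amine or a carboxylic acid on the phenyl ring, or to a pyridine ring in place of the phenyl.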